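Aryl-to-benzyl amide change on a chromone core

The source may hold more compounds than are shown below. What is called first, only, known or untested is meant among the compounds shown, and "the series" means these compounds.

Measured compounds:
compound 1 `COc1ccc2c(=O)c(/C=C/C(=O)Nc3ccc(C)cc3)coc2c1` gives 39300 nM
compound 2 `Cc1ccccc1NC(=O)/C=C/c1coc2cc(O)ccc2c1=O` gives 9320 nM
compound 3 `O=C(/C=C/c1coc2cc(O)ccc2c1=O)NCc1ccccc1` gives 63000 nM

The three numbers come from a functional assay (QGY7701 cells, Homo sapiens) for inhibition, read by MTT assay, with a stated time of 48 h; a higher number here means a weaker inhibitor, a lower number a stronger inhibitor. Compound 1 stands second highest of the three; compound 3 is its nearest neighbour, and the two values lie within the scatter of each other. Compound 2 sits well below compound 1, beyond the scatter.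

Compound 4 `COc1ccc2c(=O)c(/C=C/C(=O)NCc3ccc(F)cc3)coc2c1` has not been measured. It differs from compound 1 in one place: 4-fluorobenzyl in place of 4-methylphenyl on an amide-type nitrogen. Among the compounds with values here, the measured step that bears on this is the one from compound 2 to compound 3, in which a benzyl group replaced a substituted phenyl on the same amide-type nitrogen and the number rose, a 6.8-fold higher number from compound 2 to compound 3 (0.83 log units; beyond the scatter). Within the data shown here, compound 1 already sits high, so the same kind of change is expected to raise the number further, though compounds 1 and 4 carry a methoxy core rather than the hydroxy core of compounds 2 and 3, and the fluorine has no measured counterpart here. Compound 4 is therefore estimated at 110000 nM, within 40000 nM to 300000 nM, an expected step of a 2.8-fold higher number from compound 1 to compound 4 (0.45 log units; beyond the scatter).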

Compound 4, half-maximal inhibitory concentration: 7960 nM
Compound 4: middle estimate off by 14-fold (1.14 log units), on the high side; the measured number lies below the stated range.
By their numbers in this assay, from the lowest: compounds 4 and 2 (each within the scatter of the next); then compounds 1 and 3 (each within the scatter of the next).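

In this assay, moving to 4-fluorobenzyl on the amide-type nitrogen gave a 4.9-fold lower number from compound 1 to compound 4 (0.69 log units; beyond the scatter), so a benzyl-type group at this place does not always raise the number, as a 6.8-fold higher number from compound 2 to compound 3 (0.83 log units; beyond the scatter) alone had suggested. The two steps run in opposite directions, with compound 4 going against what compound 3 showed, and they differ both in the groups exchanged and in the core, methoxy in compounds 1 and 4 and hydroxy in compounds 2 and 3. No measurement at hand explains this reversal.

From the compounds shown here alone, how much of the step belongs to the fluorine and how much to the benzyl itself stays open, and a plain benzyl on the core of compound 1 would separate the two. Also open, going by these compounds, is how a longer chain such as 2-phenylethyl, or a benzyl carrying a carboxylic acid, would fare on this nitrogen.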